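Cyclopropylamino to butylamino on the shared core

The source may report more compounds than this note shows. Statements on the series, on what has been measured and on what is new or still open speak of the compounds shown alone.

In a functional assay on KB cells (Homo sapiens) for inhibition, read by sulforhodamine B assay, with a stated time of 48 h (on this read-out lower numbers stand for stronger inhibition of growth and higher numbers for weaker inhibition of growth), the values so far are as follows:
compound 1 `COc1ccc2c(c1)NC(=O)CN2c1nc(OCC2CC2)nc2ccccc12` gives 14.2 nM
compound 2 `COc1ccc2c(c1)NC(=O)CN2c1nc(NC2CC2)nc2ccccc12` gives 2.11 nM

Compound 2 holds the lower of the two numbers, and its gap to compound 1 lies beyond the scatter. Next is compound 3 `CCCCNc1nc(N2CC(=O)Nc3cc(OC)ccc32)c2ccccc2n1`, with the change (butyl in place of cyclopropyl on a nitrogen on an aromatic ring); in words, butyl in place of cyclopropyl on a nitrogen on an aromatic ring. Within the data shown here, the only measured step, a 6.7-fold lower number from compound 1 to compound 2 (0.83 log units; beyond the scatter), came with cyclopropylamino in place of cyclopropylmethoxy on an aromatic carbon and leaves the cyclopropyl untouched. Among the measured compounds shown here, it bears only indirectly, and no measured step exchanges a ring for an open chain. The step expected in this assay is a 2.4-fold higher number from compound 2 to compound 3 (0.37 log units; beyond the scatter), toward weaker inhibition of growth, though the expected range also allows none beyond the scatter. For compound 3 the estimated value is 5 nM, with an expected range from 1.5 nM to 18 nM on measurement.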

Compound 3, concentration for 50% growth inhibition: 5.25 nM
Compound 3: the middle estimate sits 1.1-fold (0.02 log units) below what was measured, and the stated range covers the measured number.
By their numbers in this assay, from the lowest: compound 2; then compound 3; then compound 1.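

In this assay, replacing the cyclopropyl with the open butyl chain on the same nitrogen gives a 2.5-fold higher number from compound 2 to compound 3 (0.40 log units; beyond the scatter), so this position tolerates a chain without a ring, though with a modest loss. Butylamino in place of cyclopropylmethoxy on an aromatic carbon gives a 2.7-fold lower number from compound 1 to compound 3 (0.43 log units; beyond the scatter), so both amino compounds, compound 2 and compound 3, carry lower numbers than compound 1, and none of the three goes against this. Nothing available explains either step.

The compounds shown do not separate the loss of the ring from the change in chain length, which a propyl or cyclobutyl group on the same nitrogen could address. They also leave open whether a butoxy group would keep the gap seen between compound 1 and compound 3.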